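The source may report more compounds than this note shows. Statements on the series, on what has been measured and on what is new or still open speak of the compounds shown alone.

Values in a functional assay with Oryctolagus cuniculus as the target; on this read-out lower numbers stand for stronger inhibition and higher numbers for weaker inhibition:
compound 1 `COc1ccc(-c2nc(/N=C(\N)NC(C)C)sc2-c2ccc(OC)cc2)cc1`: > 100 nM
compound 2 `COc1ccc(-c2nc(/N=C(\N)NC3CCCCC3)sc2-c2ccc(OC)cc2)cc1`: > 1000 nM
compound 3 `COc1ccc(-c2nc(/N=C(\N)[N+]3(C)CCCCC3)sc2-c2ccc(OC)cc2)cc1`: > 1000 nM

Every entry here is a limit of the assay and not a number. Compound 3 is known only through its limit, > 1000 nM, so its true value is open. Compound 2 stands at the same limit, > 1000 nM. Compound 1 has a limit of its own, > 100 nM.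

The next compound, compound 4 `COc1ccc(-c2nc(/N=C(\N)N3CCOCC3)sc2-c2ccc(OC)cc2)cc1`, keeps the shared core and differs only in the group on a carbon with a double bond to nitrogen, where morpholin-4-yl enters: a group of 6 heavy atoms (4 carbon, 1 nitrogen, 1 oxygen; one six-membered non-aromatic ring with 2 hetero atoms) in place of a group of 7 heavy atoms (6 carbon, 1 nitrogen; one six-membered non-aromatic ring with 1 hetero atom), on a carbon with a double bond to nitrogen.

The closest evidence comes from changes at that same carbon: a step that the two limits leave unreadable from compound 2 to compound 3, and a step that the two limits leave unreadable from compound 1 to compound 3. The remaining pair gives no more: a step that the two limits leave unreadable from compound 1 to compound 2. None of these has a readable size, so none fixes a size or a direction for the new change. No step beyond the usual scatter is therefore expected in this assay, in either direction. The expectation leans on (the limit of > 1000 nM in this assay, at which 2 of the 3 values shown sit). The estimated change is a step that the limit leaves unreadable from compound 3 to compound 4. Compound 4 is estimated at 3000 nM, with an expected range from 500 nM to 20000 nM.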

Compound 4, half-maximal inhibitory concentration: < 1000 nM
Compound 4: no number, only a limit (the forecaster's own chance of this, stated with the estimate: 75%); middle value at least 3.0-fold (0.47 log units) from the limit.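

In this assay, compound 4 carries a limit and not a number (< 1000 nM), and it is the only limit among these compounds that bounds the value from the upper side. On the carbon with a double bond to nitrogen, morpholin-4-yl therefore gives the first hint of a direction for a change at this position: there is a number no higher from compound 3 to compound 4 (the limit leaves the size open) and also a number no higher from compound 2 to compound 4 (the limit leaves the size open) in this comparison. The sizes of these steps stay open, and the step between compound 1 and compound 4 cannot be read at all, so the comparison rests on limits alone: the limit of < 1000 nM in this assay, at which 1 of the 4 values shown sits.

On these data alone, how far the true value of compound 4 lies under its limit remains unknown, as do the true values of the other three compounds. Compound 4 also differs from compound 3 both by a ring oxygen and by the loss of the net charge, so an uncharged piperidin-1-yl group at the same carbon would be the natural comparison for telling these two changes apart.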